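The compounds below may be only part of what the source reports. "The series", "measured", "known", "first", "only" and "open" are said of these compounds alone.

Measured in a functional assay (aorta) with Rattus norvegicus as the target; a higher number here means that more compound is needed for the effect, a lower number that less compound is needed:

- compound 1 `CNC1=NS(=O)(=O)c2cc(F)ccc2N1`: > 300 uM (a limit of the assay, not a number)
- compound 2 `O=S1(=O)NC(NC2CCC2)=Nc2ccc(F)cc21`: 71.8 uM
- compound 3 `CNC1=NS(=O)(=O)c2cc(Cl)ccc2N1`: 142 uM

Among the compounds with values here, compound 3 has one of only two true numbers here, and its 142 uM lies within the usual scatter of the value of compound 2, 71.8 uM. Compound 4 `CCC(C)(C)NC1=NS(=O)(=O)c2cc(Cl)ccc2N1` keeps the chloro of compound 3 but has 1,1-dimethylpropyl in place of methyl on an amine nitrogen.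

Within the data shown here, the one measured step, chloro in place of fluoro on an aromatic carbon, gave an at least 2.1-fold lower number from compound 1 to compound 3 (0.32 log units; beyond the scatter). It is a modest change at a different place, so it says little about this one. Among the measured compounds shown here, no measured step changes only the group on the amine nitrogen. The closest hint is compound 2, which has the fluoro and a larger group than methyl on that nitrogen and gives 71.8 uM. Compound 1, with methyl there, reads > 300 uM, which is a limit.

A clearly lower number is therefore expected in this assay, an estimated 9.5-fold lower number from compound 3 to compound 4 (0.98 log units; beyond the scatter). For compound 4 the estimated value is 15 uM, with an expected range of 4 uM to 60 uM.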

Compound 4, concentration for half-maximal effect: 0.29 uM
Compound 4: the middle estimate sits 52-fold (1.71 log units) above what was measured, outside the stated range (below it).
By their numbers in this assay, from the lowest: compound 4; then compounds 2 and 3 (each within the scatter of the next). At a limit, above all of these: compound 1.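

In this assay, 1,1-dimethylpropyl in place of methyl on the amine nitrogen gives a 490-fold lower number from compound 3 to compound 4 (2.69 log units; beyond the scatter) and counts as a large step. Within the data shown here, no earlier step had changed the group on this nitrogen alone, and this pair shows that the change can move the number a long way while the rest of the compound stays the same. The group that enters consists of carbon only, with no ring, no hydrogen-bond donors or acceptors and no net charge.

This single pair leaves open how the number would respond to other groups on this nitrogen, such as a straight pentyl chain or a chain ending in an amine, and to 1,1-dimethylpropyl combined with the fluoro of compound 1. Nothing shown here gives a measured reason for the step.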